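The compounds below may be only part of what the source reports. "The series", "measured", "known", "first", "only" and "open" are said of these compounds alone.

Compound 1 `COc1cc(-c2nnc3n2NC(c2ccco2)C(C(=O)c2ccccc2F)S3)cc(OC)c1OC` gives in a functional assay on MCF7 cells (Homo sapiens) for cytotoxicity, read by MTT assay, with a stated time of 48 h (a lower number here means a stronger inhibitor, a higher number a weaker inhibitor), a value of 94800 nM, a weak result. For compound 2 `COc1cc(-c2nnc3n2NC(c2ccco2)C(C(=O)c2cccs2)S3)cc(OC)c1OC` this assay reports only a limit, > 100000 nM. Compound 3 `COc1cc(-c2nnc3n2NC(c2ccco2)C(C(=O)c2ccc(C)cc2)S3)cc(OC)c1OC` likewise reaches only a limit in this assay, > 100000 nM. Both limits fall at the limit of > 100000 nM in this assay, at which 2 of the 3 values shown sit. The steps of an at least 1.0-fold higher number from compound 1 to compound 2 (0.02 log units; that floor lies within the scatter) and an at least 1.0-fold higher number from compound 1 to compound 3 (0.02 log units; that floor lies within the scatter) stay within the scatter, and the step that the two limits leave unreadable from compound 2 to compound 3 cannot be read at all. Compound 4 `COc1cc(-c2nnc3n2NC(c2ccco2)C(C(=O)c2ccc(O)cc2)S3)cc(OC)c1OC` carries hydroxy in place of methyl on an aromatic carbon. Every measured change on the carbonyl carbon left the number near the limit, so no step beyond the scatter is expected for compound 4, whose estimate means a number no higher from compound 3 to compound 4 (the limit leaves the size open). Compound 4 is estimated at 100000 nM, between 50000 nM and 200000 nM, quite possibly again only as a limit.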

Compound 4, half-maximal inhibitory concentration: 88900 nM
Compound 4: middle estimate off by 1.1-fold (0.05 log units), on the high side; low and high end bracket the measured number.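

Hydroxy in place of methyl at this position, para to a large group, gives a readable number in this assay where the methyl compound reached only a limit, yet the step stays small: an at least 1.1-fold lower number from compound 3 to compound 4 (0.05 log units; that floor lies within the scatter). The comparisons with the other two groups on the carbonyl read alike: an at least 1.1-fold lower number from compound 2 to compound 4 (0.05 log units; that floor lies within the scatter), and a 1.1-fold lower number from compound 1 to compound 4 (0.03 log units; within the scatter). A hydrogen-bond donor and acceptor at this carbon therefore moves nothing beyond the scatter.

On these data alone, whether an amine or a carboxylic acid here would do so stays open. The step between the two compounds held at a limit cannot be read: the limit of > 100000 nM in this assay, at which 2 of the 4 values shown sit.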